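A few compounds are considered here, and "the series" means these few. Any claim that something is new, unique, unknown or untested is made for them only; others in the source may bear on it.

In a functional assay on the whole organism (Popliteal lymph node) with Rattus norvegicus as the target (on this read-out lower numbers stand for an effect already at smaller amounts and higher numbers for an effect only at larger amounts of compound), compound 3 `CCCCCCCOc1ccc(CCC(N)(CC)CO)cc1` gives 0.059 mg/kg, the lowest of the three numbers measured. Compound 1 `CCCCCCCOc1ccc(CCC(N)(CO)CCC)cc1` gives 3.1 mg/kg and compound 2 `CCCCCCCOc1ccc(CCC(N)(CO)C(C)C)cc1` gives 2.7 mg/kg; a 1.1-fold lower number from compound 1 to compound 2 (0.06 log units; within the scatter), whereas a 53-fold lower number from compound 1 to compound 3 (1.72 log units; beyond the scatter) and a 46-fold lower number from compound 2 to compound 3 (1.66 log units; beyond the scatter). Compound 4 `CCCCCCCOc1ccc(CCC(N)(CO)CO)cc1` differs from compound 3 by hydroxy in place of methyl on a saturated chain carbon, two bonds along the chain from an amine nitrogen. Among the compounds with values here, no measured step exchanges a methyl for a hydroxy, so none bears directly on this change; the two large steps into compound 3 only show that what sits on this part of the chain can move this assay by a wide margin. The expected step is a 1.2-fold lower number from compound 3 to compound 4 (0.07 log units; within the scatter), with broad uncertainty. For compound 4 the estimate in this assay is 0.05 mg/kg, with a range from 0.01 mg/kg to 0.3 mg/kg.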

Compound 4, dose for 50% inhibition: 0.049 mg/kg
For compound 4 the middle estimate is 1.0-fold (0.01 log units) above the measured one; the measured number falls inside the stated range.
By their numbers in this assay, from the lowest: compounds 4 and 3 (each within the scatter of the next); then compounds 2 and 1 (each within the scatter of the next).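

In this assay, hydroxy in place of methyl on this saturated chain carbon gives a 1.2-fold lower number from compound 3 to compound 4 (0.08 log units; within the scatter) and so leaves the number unmoved within the scatter, showing that ethyl and hydroxymethyl read alike at this place, where the earlier compounds had shown only the large loss with propyl and isopropyl. Hydroxymethyl stands clear of both of those, with a 55-fold lower number from compound 2 to compound 4 (1.74 log units; beyond the scatter) and a 63-fold lower number from compound 1 to compound 4 (1.80 log units; beyond the scatter) as the two large steps. Nothing available bears on the cause of this. The compounds leave open whether a methyl, a methoxymethyl or an aminomethyl here would keep the number as low.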